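A Nitro Swap at the Limit of a Toxicity Test

The compounds below may be only part of what the source reports. "The series", "measured", "known", "first", "only" and "open" are said of these compounds alone.

Compound 1 (`CC(C)OC(=O)COC(=O)c1ccc([N+](=O)[O-])o1`) was tested in an ADME assay on HEK-293T cells (Homo sapiens) for cytotoxicity, read by MTT assay, with a stated time of 3 days (on this read-out higher numbers stand for lower toxicity in this test and lower numbers for higher toxicity in this test), and gave > 100000 nM as a limit of the assay rather than a number. Compound 2 (`CC(C)(NC(=O)COC(=O)c1ccc([N+](=O)[O-])o1)c1ccccc1`) gave > 100000 nM in this assay and this is likewise a limit. Compound 3 (`CC(C)(C)N(Cc1ccc([N+](=O)[O-])cc1)C(=O)COC(=O)c1ccc([N+](=O)[O-])o1`) gave > 100000 nM in this assay and this too is a limit. Compound 3 therefore stands with the other two, and the whole set comes down to the limit of > 100000 nM in this assay, at which 3 of the 3 values shown sit, with no number yet for any compound.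

Compound 4 (`COc1ccc(CN(C(=O)COC(=O)c2ccc([N+](=O)[O-])o2)C(C)(C)C)cc1`) keeps everything in compound 3 except one group, as 4-nitrophenyl becomes 4-methoxyphenyl: methoxy in place of nitro on an aromatic carbon, para to a large group (methoxy in place of nitro on an aromatic carbon). Within the data shown here, no pair of measured compounds offers a step by which to size this change. No step beyond the usual scatter is expected, and a further reading at the limit is the likeliest outcome. That expectation rests on compound 3, whose value of > 100000 nM is a limit. As an estimate, the expected change is a number no higher from compound 3 to compound 4 (the limit leaves the size open) in this assay and no larger move is expected. Compound 4 is expected to read 100000 nM with a range from 50000 nM to 200000 nM on this estimate.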

Compound 4, half-maximal cytotoxic concentration: > 100000 nM
Compound 4: a limit, no number; the forecaster's own chance of this, stated with the estimate: 85%; the middle value sits exactly at the limit.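

The change from 4-nitrophenyl to 4-methoxyphenyl gives no readable step between compound 3 and compound 4 in this assay, as both compounds rest at a limit and not at a number: the limit of > 100000 nM in this assay, at which 4 of the 4 values shown sit.

The compounds shown leave open where any of the four would give an actual number in this assay, and whether this change alters that number at all.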